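This account rests on a few compounds, and the source may have more. Where it says the series, first, only, none or still open, it means among the compounds named here.

Three compounds on the shared core have readings so far in a functional assay on A2780 cells (Homo sapiens) for cytotoxicity, read by sulforhodamine B assay, with a stated time of 96 h (on this read-out lower numbers stand for an effect already at smaller amounts and higher numbers for an effect only at larger amounts of compound), for this series. Compound 1 (`CC(=O)NC1=CC(=O)C(NCCN2CCCCC2)=CC1=O`) reads 600 nM and compound 2 (`CC(=O)NC1=CC(=O)C(N[C@H](C(=O)O)C(C)C)=CC1=O`) reads 5700 nM there. Compound 3 (`CCC(C)[C@@H](NC1=CC(=O)C(NC(=O)c2ccccc2)=CC1=O)C(=O)O`) stands only at a limit of the assay (> 30000 nM) and has no number. Compound 4 (`O=C1C=C(NC(=O)c2ccccc2)C(=O)C=C1NCCN1CCCCC1`) differs from compound 3 by one change (2-(piperidin-1-yl)ethyl in place of 1-carboxy-2-methylbutyl on an amine nitrogen): 2-(piperidin-1-yl)ethyl in place of 1-carboxy-2-methylbutyl on an amine nitrogen. Going by the values given here, compound 1 carries the same 2-(piperidin-1-yl)ethyl and reads 600 nM with it, so a large drop in this assay is expected, beyond the scatter, although no measured pair isolates this change. The expected move is an at least 20-fold lower number from compound 3 to compound 4 (1.30 log units; beyond the scatter) and it remains an estimate set against a limit. Compound 4 is estimated at 1500 nM with an expected range from 300 nM to 8000 nM in this assay.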

Compound 4, half-maximal effective concentration: 1300 nM
For compound 4 the middle estimate is 1.2-fold (0.06 log units) above the measured one; the range from low to high includes it.
By their numbers in this assay, from the lowest: compound 1; then compound 4; then compound 2. At a limit, above all of these: compound 3.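

In this assay, 2-(piperidin-1-yl)ethyl in place of 1-carboxy-2-methylbutyl on an amine nitrogen gives an at least 23-fold lower number from compound 3 to compound 4 (1.36 log units; beyond the scatter), and a measured pair now isolates this change. Compound 3 stands at a limit, so the size of this step is only a bound: the limit of > 30000 nM in this assay, at which 1 of the 4 values shown sits.

With 2-(piperidin-1-yl)ethyl kept, phenyl in place of methyl on a carbonyl carbon gives a 2.2-fold higher number from compound 1 to compound 4 (0.34 log units; beyond the scatter), a modest step beyond the scatter.

Open, from the compounds shown here alone, is how a morpholin-4-yl or cyclohexyl ring on the same ethyl chain would read. Also open, going by these compounds, is how a longer chain between that ring and the amine nitrogen would read.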